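The compounds below may be only part of what the source reports. "The series", "measured", "known", "first", "only" and "open" are said of these compounds alone.

Measured in an ADME assay on L1210/0 cells (Mus musculus) for cytotoxicity, with a stated time of 48 h; a higher number here means a weaker inhibitor, a lower number a stronger inhibitor:
- compound 1 `CC1(C)[C@@H](Cn2cnc3c(O)nc(N)nc32)CC[C@@]1(C)CO`: > 200000 nM (a limit, not a number)
- compound 2 `O=c1[nH]c(=O)n([C@H]2C[C@H](O)[C@@H](CO)O2)cc1/C=C/I`: 63900 nM
- compound 3 `O=c1[nH]c(=O)n([C@H]2C[C@H](O)[C@@H](CO)O2)cc1CO`: 9180 nM

Of the two actual numbers in this assay, compound 3 holds the lower, at 9180 nM, and compound 2 gives 63900 nM. Among the measured compounds shown here, compound 1 offers only a limit, > 200000 nM, and no step connects it to the others.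

Next in the series is compound 4 `N#CSc1cn([C@H]2C[C@H](O)[C@@H](CO)O2)c(=O)[nH]c1=O`, with cyanosulfanyl in place of hydroxymethyl on an aromatic carbon.

For the measured compounds named here, only one measured step involves this aromatic carbon: a 7.0-fold lower number from compound 2 to compound 3 (0.84 log units; beyond the scatter). This modest step lies beyond the scatter, but it is a single pair and does not include cyanosulfanyl, so it gives only a rough scale. Compound 2 also lacks the hydroxymethyl and has the higher number, at 63900 nM. A modest rise in this assay is therefore expected on leaving compound 3, probably smaller than the measured step, and a change within the scatter remains possible.

The expected step is a 2.2-fold higher number from compound 3 to compound 4 (0.34 log units; beyond the scatter).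

For compound 4 the estimate is 20000 nM, with an expected range of 3000 nM to 90000 nM.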

Compound 4, half-maximal inhibitory concentration: 78900 nM
The estimate for compound 4 lay 3.9-fold (0.60 log units) below the measured number; the range from low to high includes it.
By their numbers in this assay, from the lowest: compound 3; then compounds 2 and 4 (each within the scatter of the next). At a limit, above all of these: compound 1.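

At this aromatic carbon, hydroxymethyl now differs from a second group: in this assay, cyanosulfanyl in place of hydroxymethyl gives an 8.6-fold higher number from compound 3 to compound 4 (0.93 log units; beyond the scatter) and so joins the earlier 2-iodoethenyl pair, which gives a 7.0-fold lower number from compound 2 to compound 3 (0.84 log units; beyond the scatter) in the opposite direction from the new step. Cyanosulfanyl in place of 2-iodoethenyl gives a 1.2-fold higher number from compound 2 to compound 4 (0.09 log units; within the scatter) and so does not separate these two groups, which leaves hydroxymethyl in compound 3 as the only one of the three groups here with the lower number, and no compound among these three goes against this. Nothing measured here accounts for the size or direction of these steps.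

The three groups at this position still do not show whether the lower number depends on the hydroxyl of hydroxymethyl, since neither a plain methyl, an amine such as aminomethyl, nor a longer chain such as 2-hydroxyethyl stands among them. As far as these compounds go, a carboxylic acid at this carbon is equally open, as is whether the pattern holds on any core other than the one shared by these three compounds.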